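This account rests on a few compounds, and the source may have more. Where it says the series, first, only, none or still open, it means among the compounds named here.

Compound 1, `CCOC(=O)c1c(-c2cccc(F)c2)[nH]c2cc(OC)ccc2c1=O`, in a physicochemical assay for solubility, in phosphate buffer, at pH 7.4 (a higher number here means a more soluble compound, a lower number a less soluble compound), gives > 100000 nM, which is a limit of the assay and not a number.
Compound 2, `CCOC(=O)c1c(-c2ccc(Cl)cc2)[nH]c2cccc(OC)c2c1=O`, in this assay gives > 100000 nM, again a limit of the assay.
Compound 3, `CCOC(=O)c1c(-c2ccccc2)[nH]c2cc(OC)ccc2c1=O`, in this assay gives > 100000 nM, also a limit of the assay.

Compound 2 therefore stands at the same limit as the other two measured compounds; the limit of > 100000 nM in this assay, at which 3 of the 3 values shown sit, describes this common position, and no measured value here is an actual number. Going by the values given here, the only pair of measured compounds that differ in one place, with hydrogen in place of fluoro on an aromatic carbon, gives the step that the two limits leave unreadable from compound 1 to compound 3, so no direction or size can be read from it.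

Compound 4, `CCOC(=O)c1c(-c2cccc(OC)c2)[nH]c2cccc(OC)c2c1=O`, has not yet been measured in this assay. It differs from compound 2 in one place: 3-methoxyphenyl in place of 4-chlorophenyl on an aromatic carbon. Among the compounds with values here, no measured step bears on this change in a readable way. Since every measured value sits at the limit, compound 4 is expected to sit there too, with an expected step that the limit leaves unreadable from compound 2 to compound 4. The estimate for compound 4 is 150000 nM, between 50000 nM and 500000 nM.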

Compound 4, solubility: > 100000 nM
Compound 4: only a limit was reported (the forecaster's own chance of this, stated with the estimate: 80%); the middle value does not contradict the limit.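

Compound 4 in this assay gives > 100000 nM, which is a limit of the assay and not a number. Going by these compounds alone, compound 2 also stands at a limit, so no step from compound 2 to compound 4 can be read. All the compounds shown share one position: the limit of > 100000 nM in this assay, at which 4 of the 4 values shown sit. The compounds shown leave open how their actual solubilities compare, and whether 3-methoxyphenyl in place of 4-chlorophenyl changes solubility at all.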